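Dropping the dimethylamino group from compound 2

The source may hold more compounds than are shown below. What is called first, only, known or untested is meant among the compounds shown, and "the series" means these compounds.

In a functional assay on K562 cells (Homo sapiens) for antiproliferative activity, read by CellTiter-Glo and CCK-8 assay, with a stated time of 72 h (on this read-out lower numbers stand for stronger inhibition of growth and higher numbers for weaker inhibition of growth), compound 2 `Cc1ccc(Nc2ncc(C(=O)Nc3cc(NC(=O)c4cccc(C(F)(F)F)c4)ccc3C)c(N(C)C)n2)cc1N` gives 1210 nM, the highest of the two numbers at hand. For the measured compounds named here, its only measured neighbour is compound 1 `CNc1nc(Nc2ccc(C)c(N)c2)ncc1C(=O)Nc1cc(NC(=O)c2cccc(C(F)(F)F)c2)ccc1C`, which in this assay gives 14 nM; the change is an 86-fold higher number from compound 1 to compound 2 (1.94 log units; beyond the scatter). Compound 3 `Cc1ccc(Nc2ncc(C(=O)Nc3cc(NC(=O)c4cccc(C(F)(F)F)c4)ccc3C)cn2)cc1N` has not been measured. It differs from compound 2 by hydrogen in place of dimethylamino on an aromatic carbon. Going by the values given here, the one measured step bears on it only loosely: it shows that a methyl on a nitrogen on an aromatic ring at this place raised the number strongly, but no measured pair shows what removing the whole group does. The estimate for compound 3 is therefore hedged: a step of a 4.0-fold lower number from compound 2 to compound 3 (0.61 log units; beyond the scatter) is expected, a lower number than compound 2 but with wide uncertainty in both directions. Compound 3 is estimated at 300 nM, within a range from 40 nM to 2500 nM.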

Compound 3, concentration for 50% growth inhibition: 330 nM
For compound 3 the middle estimate is 1.1-fold (0.04 log units) below the measured one; the range from low to high includes it.
By their numbers in this assay, from the lowest: compound 1; then compound 3; then compound 2.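

Taking the dimethylamino group off the aromatic carbon gives in this assay a 3.7-fold lower number from compound 2 to compound 3 (0.56 log units; beyond the scatter) and shows that this group costs activity compared with no substituent at all. Set against the methylamino group of compound 1, the same hydrogen gives a 24-fold higher number from compound 1 to compound 3 (1.37 log units; beyond the scatter) and so the position is not merely tolerant of a small change: relative to hydrogen, methylamino lowers the number and dimethylamino raises it. Nothing available explains why these two groups move the number in opposite directions.

As far as these compounds go, what remains open is whether a plain amine at this place, or an ethylamino group with its longer chain on the nitrogen, would match the methylamino group of compound 1. From the compounds shown here alone, it is equally open whether a methoxy group, with oxygen in place of that nitrogen, would fall nearer compound 1 or compound 3.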